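The source may hold more compounds than are shown below. What is called first, only, known or untested is meant among the compounds shown, and "the series" means these compounds.

Working notes on the amide series sharing the core of compound 1.

Going by the values given here, compound 1 `O=C(Nc1cccc(-c2oc3cc(-c4ccc(F)cc4)ccc3c(=O)c2O)c1)c1ccc(F)cc1` in a functional assay on A549 cells (Homo sapiens) for antiproliferative activity, read by CCK-8 assay, with a stated time of 72 h (a higher number here means a weaker inhibitor, a lower number a stronger inhibitor), gives 6930 nM, the lowest number among the three measured members, though its nearest neighbour is not separated from it beyond the scatter. Compound 2 `O=C(Nc1cccc(-c2oc3cc(-c4ccc(F)cc4)ccc3c(=O)c2O)c1)c1ccc(Cl)cc1` gives 10800 nM in this assay, and compound 3 `Cc1cccc(C(=O)Nc2cccc(-c3oc4cc(-c5ccc(F)cc5)ccc4c(=O)c3O)c2)c1` gives 16500 nM. Among the compounds with values here, the steps are a 1.6-fold higher number from compound 1 to compound 2 (0.19 log units; within the scatter), a 2.4-fold higher number from compound 1 to compound 3 (0.38 log units; beyond the scatter) and a 1.5-fold higher number from compound 2 to compound 3 (0.18 log units; within the scatter); only the step to compound 3 clears the scatter, and then only modestly. Every substitution on the amide aryl so far has moved the number upward or left it unchanged.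

Compound 4 `CCc1ccc(C(=O)Nc2cccc(-c3oc4cc(-c5ccc(F)cc5)ccc4c(=O)c3O)c2)cc1` is still to be measured in this assay. Relative to compound 1 the change is ethyl in place of fluoro on an aromatic carbon. The step that bears on it most directly is the exchange at the same aromatic carbon, a 1.6-fold higher number from compound 1 to compound 2 (0.19 log units; within the scatter), which stayed within the scatter; the step of a 2.4-fold higher number from compound 1 to compound 3 (0.38 log units; beyond the scatter) shows that a further change of the aryl amide reached a modest increase. A small upward drift in this assay is therefore expected for compound 4, most likely close to the scatter edge, a 1.4-fold higher number from compound 1 to compound 4 (0.16 log units; within the scatter). Compound 4 is expected to give about 10000 nM, with a range from 5000 nM to 22000 nM.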

Compound 4, half-maximal inhibitory concentration: 18500 nM
The estimate for compound 4 lay 1.9-fold (0.27 log units) below the measured number; the range from low to high includes it.
By their numbers in this assay, from the lowest: compounds 1, 2, 3 and 4 (each within the scatter of the next, the first and the last beyond it).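

At the aromatic carbon para to a large group, ethyl in place of fluoro gives (a 2.7-fold higher number from compound 1 to compound 4 (0.43 log units; beyond the scatter)), so this carbon has now produced a change beyond the scatter in this assay, which the chloro exchange had not. Going by these compounds alone, compound 4 is not separated from the other two amides, with (a 1.7-fold higher number from compound 2 to compound 4 (0.23 log units; within the scatter)) and (a 1.1-fold higher number from compound 3 to compound 4 (0.05 log units; within the scatter)), so 4-ethylphenyl, 3-methylphenyl and 4-chlorophenyl cannot be ordered among themselves, and only compound 3 and compound 4 stand clear of compound 1, while compound 2 stands clear of no other compound. Nothing at hand accounts for the step from fluoro to ethyl.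

The compounds shown leave open whether a longer chain such as butyl at this carbon would raise the number further, and whether an amine or a carboxylic acid there would bring it below that of compound 1. A 4-methylphenyl amide would also help to show whether the similar numbers of compound 3 and compound 4 depend on the place of the alkyl group or on its length.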